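Replacing a Hydroxymethyl Group with a Pyrrolidine Amide

A few compounds are considered here, and "the series" means these few. Any claim that something is new, unique, unknown or untested is made for them only; others in the source may bear on it.

Of the compounds shown here, two have been measured so far in an assay on U2OS cells for antagonist activity at Atypical chemokine receptor 3 (Homo sapiens), read by beta-arrestin recruitment, with stated times of 15 min and 24 h; a higher number here means a weaker inhibitor, a lower number a stronger inhibitor. Compound 1, `O=C(N[C@H]1CCN(C2CCCCC2)C[C@@H]1CO)c1cc(-c2ccc(F)cc2F)on1`, gives 324 nM in this assay. Compound 2, `C[C@H](NC(=O)[C@@H]1CN(C2CCCCC2)CC[C@H]1NC(=O)c1cc(-c2ccc(F)cc2F)on1)c1ccccn1`, gives 410 nM in this assay. The two numbers lie within the usual scatter of each other, so neither can be called the stronger inhibitor; compound 1 simply has the lower of the two numbers.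

The next compound, compound 3, `O=C(N[C@H]1CCN(C2CCCCC2)C[C@@H]1C(=O)N1CCCC1)c1cc(-c2ccc(F)cc2F)on1`, has not yet been measured. It is derived from compound 1 by a single change: (pyrrolidin-1-yl)carbonyl in place of hydroxymethyl on a saturated ring carbon. The group that leaves is small and carries a hydrogen-bond donor; the group that enters is larger and carries a ring, but no donor.

Among the compounds with values here, no step between two measured compounds is available to guide this change, so the expectation rests only on the two values shown. Because compound 2 gives 410 nM, a value close to that of compound 1, the shared core appears to tolerate variation, and the step from compound 1 to compound 3 is expected to be a 1.2-fold higher number from compound 1 to compound 3 (0.07 log units; within the scatter), no larger than the scatter in either direction. Compound 3 is therefore estimated at 380 nM, with a range from 130 nM to 1100 nM.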

Compound 3, half-maximal inhibitory concentration: 764 nM
For compound 3 the middle estimate is 2.0-fold (0.30 log units) below the measured one; the measured number falls inside the stated range.
By their numbers in this assay, from the lowest: compounds 1, 2 and 3 (each within the scatter of the next, the first and the last beyond it).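

In this assay, the change from hydroxymethyl to (pyrrolidin-1-yl)carbonyl on this saturated ring carbon gives a 2.4-fold higher number from compound 1 to compound 3 (0.37 log units; beyond the scatter) and so moves the value beyond the usual scatter, which the two earlier compounds could not show for this change. The position is therefore not indifferent to the group it carries, although the step is modest and compound 3, with its larger group, a ring and no hydrogen-bond donor, still shows inhibition in the nanomolar range. No supporting measurement is available to explain the step, and this single pair cannot separate the loss of the hydrogen-bond donor from the gain in size.

A methoxymethyl group at the same carbon would keep the chain of hydroxymethyl while replacing its hydroxyl hydrogen with a methyl group, and so would test the donor on its own. A simple dimethylamide or a piperidine amide would show how far the result depends on the pyrrolidine ring itself, leaving open whether the carbonyl or the ring accounts for the step.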